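The compounds below may be only part of what the source reports. "The series", "measured", "known", "first", "only" and "open" are said of these compounds alone.

Measured so far in a functional assay on thoracic aorta (Rattus norvegicus, strain Wistar), with a stated time of 15 min; on this read-out lower numbers stand for an effect already at smaller amounts and higher numbers for an effect only at larger amounts of compound:
- compound 1 (`COc1ccc(Br)cc1C(C)NC(=O)NS(=O)(=O)c1ccc(C)cc1`) reads > 300000 nM as a limit
- compound 2 (`COc1ccc(Br)cc1C(C)NC(=O)NS(=O)(=O)c1ccc(Cl)cc1`) reads 80900 nM as a number
- compound 3 (`COc1ccc(Cl)cc1C(C)NC(=O)NS(=O)(=O)c1ccc(C)cc1`) reads > 300000 nM as a limit

Compound 1 sits at the limit of > 300000 nM in this assay, at which 2 of the 3 values shown sit, and so offers no number.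

Compound 4 (`Cc1ccc(S(=O)(=O)NC(=O)NC(C)c2cc(Br)ccc2OC(C)C)cc1`) carries isopropyl in place of methyl on an oxygen on an aromatic ring. Neither measured step changes the group on that oxygen. Chloro in place of methyl on an aromatic carbon gave an at least 3.7-fold lower number from compound 1 to compound 2 (0.56 log units; beyond the scatter) and chloro in place of bromo gave a step that the two limits leave unreadable from compound 1 to compound 3 so neither sizes this change.

No step beyond the scatter is therefore expected in this assay and the estimated step is a number no higher from compound 1 to compound 4 (the limit leaves the size open) on this basis. For compound 4 the estimated value is 300000 nM with an expected range of 70000 nM to 600000 nM and a reading as a limit remains likely.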

Compound 4, half-maximal effective concentration: 61800 nM
Beside the measured number, compound 4's estimate is 4.9-fold (0.69 log units) above it; the measured number lies below the stated range.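

The group on this oxygen turns out to matter, which neither earlier step could show: in this assay methoxy to isopropoxy gives an at least 4.8-fold lower number from compound 1 to compound 4 (0.68 log units; beyond the scatter) and yields a readable number where the core of compound 1 gave none. Compound 1 is a limit, so this step has a known minimum but no known size: the limit of > 300000 nM in this assay, at which 2 of the 4 values shown sit.

Going by these compounds, whether an ethyl, a longer chain or a free hydroxyl on that oxygen moves the number the same way remains open. Also open, on these data alone, is whether isopropyl and chloro in place of methyl on an aromatic carbon add up within one compound.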